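Compound 4: Oxolan-2-yl Gives Way to 4-Methoxypiperidin-1-yl

This account rests on a few compounds, and the source may have more. Where it says the series, first, only, none or still open, it means among the compounds named here.

In an assay on HEK293 cells for positive allosteric modulation of metabotropic glutamate receptor 5 (Homo sapiens), read by FLIPR (a higher number here means that more compound is needed for the effect, a lower number that less compound is needed), compound 1 `O=C([C@H]1CC2CCC1C2)N1CC(c2nc(-c3ccccc3)no2)C1` gives 120 nM.
In this assay compound 2 `O=C(C1CCCO1)N1CC(c2nc(-c3cccc(Cl)c3)no2)C1` reaches only a limit, > 10000 nM.
In this assay compound 3 `Cc1cccc(-c2noc(C3CN(C(=O)c4ccccc4F)C3)n2)c1` likewise reaches only a limit, > 10000 nM.

Compound 2 thus has no number of its own in this assay, only a limit, and it shares that position with one of the other two values, as the limit of > 10000 nM in this assay, at which 2 of the 3 values shown sit, shows. Only compound 1 gives a measured concentration among the three.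

For the measured compounds named here, compound 4 `COC1CCN(C(=O)N2CC(c3nc(-c4cccc(Cl)c4)no3)C2)CC1` is the partner of compound 2 in the one change considered here: 4-methoxypiperidin-1-yl in place of oxolan-2-yl on a carbonyl carbon. The remaining part of compound 4 is the same as in compound 2, including the chlorophenyl-bearing ring system.

Going by the values given here, no measured pair in this set differs in one place, so nothing shows how large a step such a change brings in this assay. Given that compound 2 sits at the limit > 10000 nM, compound 4 is expected to stay weak, with a step of an at least 1.6-fold lower number from compound 2 to compound 4 (0.22 log units; that floor lies within the scatter) that may not exceed the scatter. Compound 4 is therefore estimated at 6000 nM, between 1500 nM and 20000 nM.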

Compound 4, half-maximal effective concentration: > 10000 nM
Compound 4: a limit, no number (the forecaster's own chance of this, stated with the estimate: 55%); middle value at least 1.6-fold (0.22 log units) away from the limit.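

In this assay compound 4 reaches only a limit, > 10000 nM, and compound 2 also stands at a limit, so no step between compound 2 and compound 4 can be read: the limit of > 10000 nM in this assay, at which 3 of the 4 values shown sit.

Going by these compounds, whether 4-methoxypiperidin-1-yl in place of oxolan-2-yl on a carbonyl carbon changes the concentration needed in this assay stays open.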